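Thiazole hydrazone series: cytotoxicity on breast cancer cells

A few compounds are considered here, and "the series" means these few. Any claim that something is new, unique, unknown or untested is made for them only; others in the source may bear on it.

Measured compounds:
compound 1 `C/C(=N\Nc1nc(-c2ccc(C)cc2)cs1)c1sc(C)nc1C`, > 100 ug/mL
compound 2 `COc1ccc(-c2csc(N/N=C(\C)c3sc(C)nc3C)n2)cc1`, > 100 ug/mL
compound 3 `C/C(=N\Nc1nc(-c2ccc(C)cc2)cs1)c1sc(-c2ccccc2)nc1C`, > 100 ug/mL

The series is read in a toxicity assay on MCF7 cells (Homo sapiens) for cytotoxicity, read by MTT assay; on this read-out lower numbers stand for stronger inhibition of growth and higher numbers for weaker inhibition of growth. Compound 1 gives only a limit of the assay, > 100 ug/mL. Compound 2 likewise gives only a limit, > 100 ug/mL. Compound 3 also gives only a limit, > 100 ug/mL. All three values therefore sit at the limit of > 100 ug/mL in this assay, at which 3 of the 3 values shown sit, and no number is known for any of them.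

Compound 4 `COc1ccc(-c2csc(N/N=C(\C)c3sc(-c4ccccc4)nc3C)n2)cc1` has not yet been measured in this assay. It differs from compound 3 by methoxy in place of methyl on an aromatic carbon. The same change was made from compound 1 to compound 2, described as methoxy in place of methyl on an aromatic carbon; the surroundings of the place are the same in both pairs, so the change is the same. Its measured step, a step that the two limits leave unreadable from compound 1 to compound 2, cannot be sized because both ends are limits. The cores of the two pairs differ as phenyl in place of methyl on an aromatic carbon, with the step that the two limits leave unreadable from compound 1 to compound 3 equally unreadable for the same reason.

With the change from compound 1 to compound 2 leaving the value at the limit, and compound 3 itself at the limit, compound 4 is expected to remain there as well: the expected step that the limit leaves unreadable from compound 3 to compound 4 is small, and the estimate for compound 4 is 150 ug/mL, with a range from 70 ug/mL to 400 ug/mL, most likely reported only as a limit.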

Compound 4, concentration for 50% growth inhibition: > 100 ug/mL
Compound 4 was reported as a limit; the forecaster's own chance of this, stated with the estimate: 85%; the middle value is on the limit's open side.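

Neither the step from compound 3 to compound 4 nor the step from compound 2 to compound 4 can be read, as both ends of each are limits: the limit of > 100 ug/mL in this assay, at which 4 of the 4 values shown sit.

The compounds shown leave open what size either change, methoxy in place of methyl or phenyl in place of methyl, has in this assay: none of the four gives a number.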